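Two Long-Chain Compounds and a Stereoisomer Still to Test

This account rests on a few compounds, and the source may have more. Where it says the series, first, only, none or still open, it means among the compounds named here.

Within the data shown here, in a functional assay on SK-OV-3 cells (Homo sapiens) for cytotoxicity (on this read-out higher numbers stand for an effect only at larger amounts of compound and lower numbers for an effect already at smaller amounts), compound 1 `CCCCC/C=C\C/C=C\C/C=C\C[C@@]1(OC)C=CC(=O)O1` gives 16.1 ug/mL, the only true number in this small set so far.

Compound 2 `CC/C=C\C/C=C\C/C=C\C/C=C\C[C@]1(OC)C=CC(=O)O1` gives > 30 ug/mL in this assay, which is a limit and not a number, so its position is only bounded.

Compound 3 `CC/C=C/C/C=C\C/C=C\C/C=C\C[C@@]1(OC)C=CC(=O)O1` has the same atoms and bonds as compound 2 and differs only in configuration as drawn: the two compounds have the same atoms and bonds and differ only in configuration as drawn: 2 of 5 stereo elements differ; a stereocentre at a saturated ring carbon is drawn R in compound 2 and S in compound 3; a double bond is drawn Z in compound 2 and E in compound 3. A stereocentre at a saturated ring carbon is drawn R in compound 2 and S in compound 3. A double bond is drawn Z in compound 2 and E in compound 3.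

Among the measured compounds shown here, no measured pair in the set isolates either configurational change, so the expectation is loose. A modest shift toward lower numbers in this assay is expected, and it may not clear the scatter, with the expected step being an at least 1.3-fold lower number from compound 2 to compound 3 (0.13 log units; that floor lies within the scatter). The number for compound 1 at 16.1 ug/mL anchors the low side of the expected range. Another limit remains quite possible for compound 3.

The estimate for compound 3 is 22 ug/mL, with an expected range of 9 ug/mL to 50 ug/mL.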

Compound 3, concentration for half-maximal effect: > 30 ug/mL
Compound 3 ended at the assay's limit; the forecaster's own chance of this, stated with the estimate: 40%; at least 1.3-fold (0.13 log units) between middle value and limit.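

In this assay compound 3 gives a limit and not a number, as compound 2 does, so the step between them cannot be read and the two inversions show no measurable consequence; the reading stops at the same bound for both: the limit of > 30 ug/mL in this assay, at which 2 of the 3 values shown sit. The comparison therefore says nothing in either direction about configuration at the saturated ring carbon or at the double bond, even though configuration is the only thing that separates the pair: the fact that compounds 2 and 3 differ only in the configuration as drawn. Against compound 1, the listed change of but-1-en-1-yl in place of butyl on a saturated chain carbon bound to a double-bonded chain carbon gives an at least 1.8-fold higher number from compound 1 to compound 3 (0.27 log units; that floor lies within the scatter), a floor that does not clear the usual scatter, so this change is not shown to matter at this position, though the true gap could be larger.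

Among these compounds, compounds 2 and 3 change the ring carbon and the double bond together, so neither change can be separated from the other, and compound 1 remains the only true number in this set. Going by these compounds, what a chain carrying a carboxylic acid or an amine would give in this assay stays open.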